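Working notes: difluoromethoxy in place of methanesulfonamido

A few compounds are considered here, and "the series" means these few. Any claim that something is new, unique, unknown or untested is made for them only; others in the source may bear on it.

compound 1 `CSC(=S)SCC(=O)c1ccc(Cl)c(Cl)c1`: 6310 nM
compound 2 `CCSC(=S)SCC(=O)c1ccc(NS(C)(=O)=O)cc1`: 39800 nM

In a functional assay on HeLa cells (Homo sapiens) for antiproliferative activity, read by resazurin assay (on this read-out higher numbers stand for weaker inhibition and lower numbers for stronger inhibition), compound 2 gives the higher of the two numbers, 39800 nM, beyond the scatter from compound 1. Compound 3 `CCSC(=S)SCC(=O)c1ccc(OC(F)F)cc1` carries difluoromethoxy in place of methanesulfonamido on an aromatic carbon. Among the compounds with values here, no measured step covers this change, and compound 1 differs from compound 2 in more than one place. The expectation of a lower number in this assay, beyond the scatter, rests only on compound 1, which lacks methanesulfonamido and gives 6310 nM. The expected size is a 3.6-fold lower number from compound 2 to compound 3 (0.56 log units; beyond the scatter). For compound 3 the estimated value is 11000 nM, within a range of 3500 nM to 32000 nM.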

Compound 3, half-maximal inhibitory concentration: 3980 nM
For compound 3 the middle estimate is 2.8-fold (0.44 log units) above the measured one, and the stated range covers the measured number.
By their numbers in this assay, from the lowest: compounds 3 and 1 (each within the scatter of the next); then compound 2.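

In this assay, within the data shown here, the change to difluoromethoxy in place of methanesulfonamido on an aromatic carbon gives a 10-fold lower number from compound 2 to compound 3 (1.00 log units; beyond the scatter) as the first measured single-place step. This position, para to a group of 9 heavy atoms, therefore does not need methanesulfonamido or its hydrogen-bond donor for a lower number, since difluoromethoxy has 0 hydrogen-bond donors. No measurement shown accounts for the step. Open, on these data alone, is how methoxy, a primary amine or a carboxylic acid would compare at this position, and whether the step holds on another thioester chain.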